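A few compounds are considered here, and "the series" means these few. Any claim that something is new, unique, unknown or untested is made for them only; others in the source may bear on it.

Values from a functional assay on HeLa cells (Homo sapiens) for antiproliferative activity, read by MTT assay, with a stated time of 48 h (on this read-out higher numbers stand for weaker inhibition and lower numbers for stronger inhibition), for the series so far
- compound 1 `COc1cccc(-c2nn(-c3ccccc3)cc2C(Nc2nc3ccccc3s2)c2c(O)ccc3ccccc23)c1` gives 14900 nM
- compound 2 `COc1ccc(-c2nn(-c3ccccc3)cc2C(Nc2nc3ccccc3s2)c2c(O)ccc3ccccc23)cc1` gives 9340 nM
- compound 3 `COc1ccc(-c2nn(-c3ccccc3)cc2C(Nc2nc3ccc(OC)cc3s2)c2c(O)ccc3ccccc23)cc1` gives 9240 nM

All three values lie within the scatter of one another, so compound 3 stands level with compound 2 and is not separated from compound 1 either. The next compound is compound 4 `COc1ccc2nc(NC(c3cn(-c4ccccc4)nc3-c3ccccc3)c3c(O)ccc4ccccc34)sc2c1`, which differs from compound 3 by hydrogen in place of methoxy on an aromatic carbon, para to a large group. Cut one bond further out, this reads 4-methoxyphenyl to phenyl.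

The step touching the same group is a 1.6-fold lower number from compound 1 to compound 2 (0.20 log units; within the scatter), 4-methoxyphenyl in place of 3-methoxyphenyl. The other is a 1.0-fold lower number from compound 2 to compound 3 (0.00 log units; within the scatter), the same kind of exchange run the other way, at another site. Both stay within the scatter, though neither tests removal of this methoxy directly. No step beyond the scatter is therefore expected in this assay, and no direction is favoured. The estimated step is a 1.1-fold higher number from compound 3 to compound 4 (0.03 log units; within the scatter). Compound 4 is estimated at 10000 nM, with an expected range from 4500 nM to 20000 nM.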

Compound 4, half-maximal inhibitory concentration: 8290 nM
Compound 4: the middle estimate sits 1.2-fold (0.08 log units) above what was measured, within the range that was stated.
By their numbers in this assay, from the lowest: compounds 4, 3, 2 and 1 (each within the scatter of the next).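

In this assay, within the data shown here, the exchange of 4-methoxyphenyl for phenyl gives a 1.1-fold lower number from compound 3 to compound 4 (0.05 log units; within the scatter) and so tests removal of this methoxy directly, where the earlier steps only moved it or changed another site. With hydrogen para to a large group, and the methoxy at the other site kept, compound 4 stands level with compound 3, so the value does not depend on this methoxy. No measurement on hand explains this result.

Each of the four values lies within the scatter of the next, so no change at this position has yet given a step beyond the scatter. On these data alone, whether an amine, a carboxylic acid or a longer alkoxy chain here would do so stays open, as does the effect of this exchange with hydrogen at the other site.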